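This account rests on a few compounds, and the source may have more. Where it says the series, first, only, none or still open, it means among the compounds named here.

Measured compounds:
- compound 1 `N#Cc1ccc2ncc(S(=O)(=O)c3ccc(F)cc3)c(-c3ccc(Cl)cc3)c2c1`, which in an assay (strain Sprague-Dawley) for displacement of a labelled ligand from metabotropic glutamate receptor 5 (Rattus norvegicus), with a stated time of 60 min (on this read-out higher numbers stand for weaker inhibition and lower numbers for stronger inhibition), gives "not determined" (no result reported)
- compound 2 `N#Cc1ccc2c(-c3ccc(Cl)cc3)c(S(=O)(=O)c3ccc(F)cc3)cnc2c1`, which in this assay gives "not determined" (no result reported)
- compound 3 `O=S(=O)(c1cc(Cl)cc(Cl)c1)c1cnc2cc(F)ccc2c1-c1cccc(F)c1`, which in this assay gives 10.7 nM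

For the measured compounds named here, compound 3 is therefore the only compound with a number in this assay; compound 1 and compound 2 carry no result, so no comparison between measured compounds is possible here. Compound 4 `O=S(=O)(c1cc(F)cc(F)c1)c1cnc2cc(F)ccc2c1-c1cccc(F)c1` has not been measured. It differs from compound 3 in a single place: 3,5-difluorophenyl in place of 3,5-dichlorophenyl on a sulfonyl sulfur. Going by the values given here, no measured pair shows what this swap does in this assay, so the expectation rests on the value of compound 3 alone. A modest weakening, somewhat beyond the usual scatter, is expected, namely a step of a 2.8-fold higher number from compound 3 to compound 4 (0.45 log units; beyond the scatter). Compound 4 is thus estimated at 30 nM, with an expected range from 8 nM to 120 nM.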

Compound 4, inhibition constant: 32.6 nM
Compound 4: middle estimate off by 1.1-fold (0.04 log units), on the low side, within the range that was stated.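

On the sulfonyl sulfur, the two halogens are not interchangeable in this assay: 3,5-difluorophenyl in place of 3,5-dichlorophenyl gives a 3.0-fold higher number from compound 3 to compound 4 (0.48 log units; beyond the scatter), the first measured effect of a change at this position. The step is modest, so compound 4 keeps much of the inhibition seen with compound 3. No available data explain the size of this step.

Going by these compounds, it remains open how a plain phenyl or 3,5-dimethylphenyl would behave on the sulfonyl sulfur. For the compounds shown here, the effect of placing only one chlorine on that ring also remains unknown.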